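A few compounds are considered here, and "the series" means these few. Any claim that something is new, unique, unknown or untested is made for them only; others in the source may bear on it.

Measured compounds in an assay on isolated protein (strain Sprague-Dawley) for inhibition of Amine oxidase [flavin-containing] B (Rattus norvegicus), read by spectrophotometry, with a stated time of 5 min; on this read-out higher numbers stand for weaker inhibition and lower numbers for stronger inhibition:
- compound 1 `CCOC(=O)COc1cc(=O)oc2cc(OCc3cccc(Cl)c3)ccc12`: 1820 nM
- compound 2 `CNc1cc(=O)oc2cc(OCc3cccc(Cl)c3)ccc12`: 8.71 nM
- compound 3 `N#Cc1cc(=O)oc2cc(OCc3cccc(Cl)c3)ccc12`: 102 nM

Compound 3 stands second highest of the three numbers in this assay. Its nearest neighbour is compound 2, reached by a 12-fold higher number from compound 2 to compound 3 (1.07 log units; beyond the scatter); the furthest is compound 1, from which compound 3 is reached by an 18-fold lower number from compound 1 to compound 3 (1.25 log units; beyond the scatter). The third step, a 210-fold lower number from compound 1 to compound 2 (2.32 log units; beyond the scatter), shows that the (ethoxycarbonyl)methoxy group gives the weakest inhibition of the set by a wide margin.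

Compound 4 `NC(=O)c1cc(=O)oc2cc(OCc3cccc(Cl)c3)ccc12` differs from compound 3 in one place: carbamoyl in place of cyano on an aromatic carbon. The carbamoyl group keeps the small size of the cyano group while bringing one hydrogen-bond donor, as the methylamino group of compound 2 does. Going by the values given here, the steps that bear on it are a 12-fold higher number from compound 2 to compound 3 (1.07 log units; beyond the scatter) and an 18-fold lower number from compound 1 to compound 3 (1.25 log units; beyond the scatter): a small group with a donor gives the lowest number, a small group without a donor gives an intermediate number, and the large ester-bearing chain gives the highest. On this basis the expected step is a modest lowering, a 1.7-fold lower number from compound 3 to compound 4 (0.23 log units; within the scatter), not exceeding the gap down to compound 2. The estimate for compound 4 in this assay is 60 nM, with a range from 10 nM to 400 nM.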

Compound 4, half-maximal inhibitory concentration: 234 nM
Beside the measured number, compound 4's estimate is 3.9-fold (0.59 log units) below it; low and high end bracket the measured number.
By their numbers in this assay, from the lowest: compound 2; then compound 3; then compound 4; then compound 1.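

In this assay, a hydrogen-bond donor at this position opposite the ring oxygen does not by itself give a low number: carbamoyl, which has one, gives a weaker result than cyano, which has none (a 2.3-fold higher number from compound 3 to compound 4 (0.36 log units; beyond the scatter)), and it also falls well short of methylamino, which likewise has one (a 27-fold higher number from compound 2 to compound 4 (1.43 log units; beyond the scatter)). Carbamoyl still improves on the (ethoxycarbonyl)methoxy group (a 7.8-fold lower number from compound 1 to compound 4 (0.89 log units; beyond the scatter)), so the order from lowest number to highest runs compound 2, compound 3, compound 4, compound 1, and compound 4 goes against the reading in which small groups with a donor give the lowest numbers. No measurement at hand accounts for the separation between the carbamoyl and methylamino groups.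

The compounds shown leave open whether the low number of compound 2 depends on the amine hydrogen, on the methyl group, or on neither, a question that the unsubstituted amine and the dimethylamino group would address at this position. They also leave open how a carboxylic acid or an N-methylcarbamoyl group would compare with the carbamoyl group of compound 4.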